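Swapping chloro for phenyl next to the amide-bearing ring

A few compounds are considered here, and "the series" means these few. Any claim that something is new, unique, unknown or untested is made for them only; others in the source may bear on it.

Three compounds share one core and differ in two side groups. Compound 3 `C[C@H](NC(=O)C(=O)Nc1ccccc1Cl)C(=O)N[C@@H](CC(=O)O)C(=O)COC(=O)c1c(Cl)cccc1Cl` gives 320 nM in a functional assay on THP-1 cells (Homo sapiens) for inhibition; on this read-out higher numbers stand for weaker inhibition and lower numbers for stronger inhibition; compound 1 `C[C@H](NC(=O)C(=O)Nc1ccccc1-c1ccccc1)C(=O)N[C@@H](CC(=O)O)C(=O)COC(=O)c1c(F)c(F)cc(F)c1F` gives 500 nM, a gap within the scatter, while compound 2 `C[C@H](NC(=O)C(=O)Nc1ccccc1C(C)(C)C)C(=O)N[C@@H](CC(=O)O)C(=O)COC(=O)c1c(Cl)cccc1Cl` gives 11800 nM, far beyond it. The single shown step, a 37-fold lower number from compound 2 to compound 3 (1.57 log units; beyond the scatter), was large. Compound 4 `C[C@H](NC(=O)C(=O)Nc1ccccc1-c1ccccc1)C(=O)N[C@@H](CC(=O)O)C(=O)COC(=O)c1c(Cl)cccc1Cl` has not been measured; it differs from compound 3 by phenyl in place of chloro on an aromatic carbon. That measured step concerns tert-butyl, not phenyl, so it bears only loosely on this change, and compound 1, which carries the same phenyl, still gave a low number. For compound 4 a step of a 1.3-fold higher number from compound 3 to compound 4 (0.10 log units; within the scatter) is therefore expected, which means an estimated value of about 400 nM, with a range from 150 nM to 1200 nM.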

Compound 4, half-maximal inhibitory concentration: 4360 nM
Compound 4: middle estimate off by 11-fold (1.04 log units), on the low side; measured number above the stated range.
By their numbers in this assay, from the lowest: compounds 3 and 1 (each within the scatter of the next); then compound 4; then compound 2.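

Phenyl on this aromatic carbon is far from equal to chloro: with 2,6-dichlorophenyl held fixed, the change brings a 14-fold higher number from compound 3 to compound 4 (1.13 log units; beyond the scatter) and chloro stands clearly ahead, while a 2.7-fold lower number from compound 2 to compound 4 (0.43 log units; beyond the scatter) puts phenyl only modestly ahead of tert-butyl. The low number of compound 1 also depends on its other group: with phenyl held fixed, 2,6-dichlorophenyl in place of 2,3,5,6-tetrafluorophenyl on the carbonyl carbon gives an 8.7-fold higher number from compound 1 to compound 4 (0.94 log units; beyond the scatter) as the step. No measurement at hand explains these steps.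

As far as these compounds go, whether 2,3,5,6-tetrafluorophenyl would also lower the number of compound 3 stays open. So does how a methoxy group or an amine would behave on this aromatic carbon.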